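Three Limits and One Untested Amine Chain

This account rests on a few compounds, and the source may have more. Where it says the series, first, only, none or still open, it means among the compounds named here.

Measured in a functional assay on TOV21G cells (Homo sapiens) for antiproliferative activity, read by sulforhodamine B assay, with a stated time of 3 days; a lower number here means a stronger inhibitor of growth, a higher number a weaker inhibitor of growth:
Compound 1 `O=c1[nH]c2ccc(-c3csc(-c4ccc(F)c(F)c4)n3)cc2o1` gives > 50000 nM as a limit
Compound 2 `COc1cc(F)ccc1-c1nc(-c2ccc3[nH]c(=O)oc3c2)cs1` gives > 50000 nM as a limit
Compound 3 `Cc1cc(F)ccc1-c1nc(-c2ccc3[nH]c(=O)n(CCN(C)C)c3c2)cs1` gives > 50000 nM as a limit

Each entry is a limit of the assay and not a number. Together they show the limit of > 50000 nM in this assay, at which 3 of the 3 values shown sit, and nothing more, so no ranking among the three can be drawn. Compound 2, the starting point here, has no measured number of its own and shares its standing with the other two.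

The next compound to be tested is compound 4 `NCCOCc1cc(F)ccc1-c1nc(-c2ccc3[nH]c(=O)oc3c2)cs1`, which keeps the rest of compound 2 and alters one group. The change is (2-aminoethoxy)methyl in place of methoxy on an aromatic carbon and it places (2-aminoethoxy)methyl in place of methoxy on an aromatic carbon.

Among the measured compounds shown here, no pair of measured compounds offers a comparable step to lean on. In this assay the expectation is therefore a small move at best, toward stronger inhibition of growth, and staying at the limit is quite possible. The estimated change is an at least 1.6-fold lower number from compound 2 to compound 4 (0.22 log units; that floor lies within the scatter) in this reading, and it is only a rough expectation. For compound 4 the expected value is 30000 nM with an estimated range from 8000 nM to 50000 nM in this assay.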

Compound 4, concentration for 50% growth inhibition: > 50000 nM
Compound 4: no number, only a limit; the forecaster's own chance of this, stated with the estimate: 60%; middle value at least 1.6-fold (0.22 log units) from the limit.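

In this assay compound 4 gives > 50000 nM, which is a limit of the assay and not a number. Among the compounds shown here, compound 2 also stands at a limit, and no step from compound 2 to compound 4 can be read. Still open is whether (2-aminoethoxy)methyl in place of methoxy changes growth inhibition at all, and how these compounds rank, with every result at one mark: the limit of > 50000 nM in this assay, at which 4 of the 4 values shown sit.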